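The source may report more compounds than this note shows. Statements on the series, on what has been measured and on what is new or still open speak of the compounds shown alone.

Working notes on the step from compound 2 (`COc1ccc(C2CC(c3ccccc3)=NN2C(=O)c2nc3ccccc3s2)cc1`) to compound 4 (`COc1ccc(C2CC(c3ccccc3)=NN2C(=O)c2ccncc2)cc1`), read in a functional assay on T47D cells (Homo sapiens) for antiproliferative activity, read by CCK-8 assay, with a stated time of 72 h; a lower number here means a stronger inhibitor, a higher number a weaker inhibitor. Compound 2 gives > 50000 nM, which is a limit of the assay and not a number. Compound 3 (`COc1ccccc1C1=NN(C(=O)c2ccncc2)C(c2ccc([N+](=O)[O-])cc2)C1`) gives > 50000 nM, also a limit. Within the data shown here, compound 1 (`COc1ccc(C2CC(c3ccccc3)=NN2C(=O)c2ccco2)cc1`) gives 27300 nM, the only true number so far. The data are therefore dominated by the limit of > 50000 nM in this assay, at which 2 of the 3 values shown sit.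

The change is pyridin-4-yl in place of 1,3-benzothiazol-2-yl on a carbonyl carbon. Among the measured compounds shown here, one measured step bears on this place: an at least 1.8-fold higher number from compound 1 to compound 2 (0.26 log units; that floor lies within the scatter). Going by these compounds, it is only a floor, so its true size is unknown. Compound 3 carries the same pyridin-4-yl on a carbonyl carbon but differs from compound 4 elsewhere, and it returned no number in this assay.

Compound 1, at 27300 nM, is the only numeric anchor with the core of compound 4, so a reading near that value is expected. A reading at the limit of the assay is also possible for compound 4. The expected step is an at least 1.1-fold lower number from compound 2 to compound 4 (0.07 log units; that floor lies within the scatter), small and towards a lower number if it can be seen at all. For compound 4 the estimated value is 42000 nM, with an expected range of 20000 nM to 50000 nM.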

Compound 4, half-maximal inhibitory concentration: > 50000 nM
Compound 4 gave a limit, no number; the forecaster's own chance of this, stated with the estimate: 55%; middle value at least 1.1-fold (0.07 log units) away from the limit.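

In this assay, pyridin-4-yl on a carbonyl carbon now joins 1,3-benzothiazol-2-yl on the shared core as a second replacement for furan-2-yl that returns a limit and not a number. The step between compound 2 and compound 4 cannot be read, as both of its ends are limits. The only readable step is an at least 1.8-fold higher number from compound 1 to compound 4 (0.26 log units; that floor lies within the scatter), so pyridin-4-yl cannot be set apart from furan-2-yl on these data, and the position so far yields a single true number: the limit of > 50000 nM in this assay, at which 3 of the 4 values shown sit.

Going by these compounds, how far the true values of compound 2 and compound 4 lie past the limit remains open, as does whether these two differ at all. Also open, on these data alone, is whether thiophen-2-yl, a plain phenyl or an open alkyl chain on that carbonyl carbon would give a number on the core of compound 1, and how such a number would compare with that of compound 1.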